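Swapping the ring nitrogen substituent of a peptide-linked thiazolidinedione

The source may report more compounds than this note shows. Statements on the series, on what has been measured and on what is new or still open speak of the compounds shown alone.

Measured compounds:
Compound 1, `CCCC[C@H](NC(=O)[C@H](CCCCN)NC(=O)[C@H](CCCNC(=N)N)NC(=O)c1ccc(/C=C2\SC(=O)N(CCCC)C2=O)cc1)C(N)=O`: 1.18 10^-6 cm/s
Compound 2, `CCCC[C@H](NC(=O)[C@H](CCCCN)NC(=O)[C@H](CCCNC(=N)N)NC(=O)c1ccc(/C=C2\SC(=S)N(CCCC)C2=O)cc1)C(N)=O`: 1.61 10^-6 cm/s
Compound 3, `CCCC[C@H](NC(=O)[C@H](CCCCN)NC(=O)[C@H](CCCNC(=N)N)NC(=O)c1ccc(/C=C2\SC(=O)N(CCOC(C)=O)C2=O)cc1)C(N)=O`: "impermeable" (no number reported)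

In an ADME assay for permeability, using PAMPA (on this read-out lower numbers stand for lower permeability and higher numbers for higher permeability), compound 1 gives 1.18 10^-6 cm/s and compound 2 gives 1.61 10^-6 cm/s; the step of a 1.4-fold higher number from compound 1 to compound 2 (0.13 log units; within the scatter) concerns the five-membered ring itself, not the group on its nitrogen. In this assay compound 3 was recorded only as "impermeable" (no number reported), so no number fixes where it stands. Compound 4, `CCCC[C@H](NC(=O)[C@H](CCCCN)NC(=O)[C@H](CCCNC(=N)N)NC(=O)c1ccc(/C=C2\SC(=O)N(Cc3ccc(F)cc3)C2=O)cc1)C(N)=O`, carries 4-fluorophenyl in place of acetoxymethyl on a saturated chain carbon bound to an amide-type nitrogen in a ring. Among the measured compounds shown here, no measured step touches that position, so the change cannot be scaled from the data. Compounds 1 and 2 show that the shared core with a butyl on that nitrogen does register a number in this assay. Compound 4 is therefore expected to give 1 10^-6 cm/s in this assay, estimated within 0.3 10^-6 cm/s to 3 10^-6 cm/s.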

Compound 4, apparent permeability: 0.43 10^-6 cm/s
Beside the measured number, compound 4's estimate is 2.3-fold (0.37 log units) above it; the range from low to high includes it.
By their numbers in this assay, from the lowest: compound 4; then compounds 1 and 2 (each within the scatter of the next).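

In this assay the place on a saturated chain carbon bound to an amide-type nitrogen in a ring now has a measured step, with 4-fluorophenyl in place of propyl: a 2.7-fold lower number from compound 1 to compound 4 (0.44 log units; beyond the scatter). Compound 3 has no number, so its difference from compound 4 cannot be read as a step, although compound 4, with 4-fluorophenyl there, does register a number. Nothing measured here explains the lower number. From the compounds shown here alone, whether an amine, a carboxylic acid or a longer chain at this place would register a number, and how it would compare with compound 1, stays open.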